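Swapping amino for bromo on a cytotoxicity baseline

The source may report more compounds than this note shows. Statements on the series, on what has been measured and on what is new or still open speak of the compounds shown alone.

Measured compounds:
compound 1 `CC(C)c1ccc(Cn2cncc2CNc2ccc(-c3nc4ccccc4s3)c(-c3ccccc3)c2)cc1` gives > 1000 nM in a toxicity assay on NIH3T3 cells (Mus musculus) for cytotoxicity, read by resazurin assay; on this read-out lower numbers stand for an effect already at smaller amounts and higher numbers for an effect only at larger amounts of compound
compound 2 `COC(=O)c1ccc(NCc2cncn2Cc2ccc(N)cc2)cc1-c1ccccc1` gives > 10000 nM in this assay
compound 3 `c1ccc(-c2ccc(Cn3cncc3CNc3ccc(-c4ccc[nH]4)c(-c4ccccc4)c3)cc2)cc1` gives > 10000 nM in this assay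

Each of these values is a limit of the assay rather than a number: compound 1 sits at the limit of > 1000 nM in this assay, at which 1 of the 3 values shown sits, while compound 2 and compound 3 sit at the limit of > 10000 nM in this assay, at which 2 of the 3 values shown sit. Compound 2 therefore stands among the two values at the higher limit, and nothing sharper than that is known about it. No pair of these compounds differs in only one place, so no measured step exists from which a trend could be read.

Compound 4 `COC(=O)c1ccc(NCc2cncn2Cc2ccc(Br)cc2)cc1-c1ccccc1` has not yet been measured. It differs from compound 2 by bromo in place of amino on an aromatic carbon. Since compound 2 is known only as a limit, the step is expected to be none beyond the scatter, with a reading that most likely stays at the limit; the expected step is a step that the limit leaves unreadable from compound 2 to compound 4. Compound 4 is expected to give 15000 nM, in a range from 4000 nM to 50000 nM.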

Compound 4, half-maximal effective concentration: > 10000 nM
Compound 4: only a limit was reported (the forecaster's own chance of this, stated with the estimate: 80%); the middle value lies beyond the limit too.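

In this assay, compound 2 and compound 4 are both known only as limits, so no step can be read for bromo in place of amino. The compounds shown leave open whether this swap changes the concentration at which cytotoxicity appears, and what that concentration is for either compound.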